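This account rests on a few compounds, and the source may have more. Where it says the series, first, only, none or still open, it means among the compounds named here.

Compound 3 `O=C(Nc1ccccc1)c1cncc(N2CC3CC(C2)N3)c1` stands highest of the three numbers in an assay on membranes from Cerebral cortex for displacement of a labelled ligand from Neuronal acetylcholine receptor; alpha4/beta2 (Rattus norvegicus); on this read-out lower numbers stand for stronger inhibition and higher numbers for weaker inhibition: compound 3 gives 1.1 nM, whereas compound 1 `O=C(Nc1ccc(I)cc1)c1cncc(N2CC3CC(C2)N3)c1` gives 0.366 nM and compound 2 `O=C(Nc1cccc(F)c1)c1cncc(N2CC3CC(C2)N3)c1` gives 0.044 nM. Compound 4 `CCc1cccc(NC(=O)c2cncc(N3CC4CC(C3)N4)c2)c1` carries ethyl in place of hydrogen on an aromatic carbon, on an aromatic carbon meta to a large group. The measured steps that bear on this change are a 25-fold higher number from compound 2 to compound 3 (1.40 log units; beyond the scatter) and a 3.0-fold higher number from compound 1 to compound 3 (0.48 log units; beyond the scatter); both show that removing a substituent from this ring raises the number, though neither involves ethyl, so the size for an ethyl group is uncertain. On that basis a modest downward step is expected, a 2.8-fold lower number from compound 3 to compound 4 (0.44 log units; beyond the scatter). Compound 4 is estimated in this assay at 0.4 nM, within a range of 0.1 nM to 1.5 nM.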

Compound 4, inhibition constant: 1.3 nM
Beside the measured number, compound 4's estimate is 3.3-fold (0.51 log units) below it; low and high end bracket the measured number.
By their numbers in this assay, from the lowest: compound 2; then compound 1; then compounds 3 and 4 (each within the scatter of the next).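

In this assay, ethyl on this aromatic carbon gives no step beyond the scatter (a 1.2-fold higher number from compound 3 to compound 4 (0.07 log units; within the scatter)), so carrying a substituent here does not by itself lower the number. Ethyl does not match fluoro (a 30-fold higher number from compound 2 to compound 4 (1.47 log units; beyond the scatter)), and the 3-ethylphenyl group also falls short of 4-iodophenyl (a 3.6-fold higher number from compound 1 to compound 4 (0.55 log units; beyond the scatter)). Nothing shown here accounts for the gap between ethyl and fluoro.

From the compounds shown here alone, whether chloro, methoxy or a longer chain at this position would stand nearer to fluoro or to ethyl remains open.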